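The source may hold more compounds than are shown below. What is called first, only, known or untested is meant among the compounds shown, and "the series" means these compounds.

Measured in a functional assay on the whole organism for inhibition, with Rattus norvegicus as the target; on this read-out lower numbers stand for an effect already at smaller amounts and higher numbers for an effect only at larger amounts of compound:
- Compound 1 `CC(C)c1ccc(OC(C)(Cc2ccc(C(F)(F)F)cc2)C(=O)O)cc1`: < 5 mg/kg
- Compound 2 `CCc1ccc(CC(C)(Oc2ccc(C(C)C)cc2)C(=O)O)cc1`: 0.1 mg/kg
- Compound 3 `CCCc1ccc(CC(C)(Oc2ccc(C(C)C)cc2)C(=O)O)cc1`: 0.5 mg/kg

The entry for compound 1 is a limit and not a number, so its steps to the other two cannot be sized. For the measured compounds named here, compound 3 has the higher of the two actual numbers, and the one readable step is a 5.0-fold higher number from compound 2 to compound 3 (0.70 log units; beyond the scatter).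

Compound 4 `CC(C)c1ccc(CC(C)(Oc2ccc(C(C)C)cc2)C(=O)O)cc1` differs from compound 3 by isopropyl in place of propyl on an aromatic carbon, para to a large group. Isopropyl, like propyl, carries one more methyl than ethyl, so a 5.0-fold higher number from compound 2 to compound 3 (0.70 log units; beyond the scatter) is the closest guide, and it sets the likely scale. A modest move back towards compound 2 is anticipated, possibly within the scatter. The expected step is a 1.7-fold lower number from compound 3 to compound 4 (0.22 log units; within the scatter). For compound 4 the estimated value is 0.3 mg/kg, with an expected range from 0.08 mg/kg to 1.2 mg/kg.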

Compound 4, dose for half-maximal effect: 5 mg/kg
Beside the measured number, compound 4's estimate is 17-fold (1.22 log units) below it; the measured number lies above the stated range.
By their numbers in this assay, from the lowest: compound 2; then compound 3; then compound 4.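

In this assay, the arrangement of the carbons at this place matters and not only their count: propyl and isopropyl have the same atoms, joined differently, yet the change gives a 10-fold higher number from compound 3 to compound 4 (1.00 log units; beyond the scatter). Methyl on the chain carbon bound to the aromatic carbon gives a 50-fold higher number from compound 2 to compound 4 (1.70 log units; beyond the scatter), a larger step than methyl two bonds along the chain, which gives a 5.0-fold higher number from compound 2 to compound 3 (0.70 log units; beyond the scatter). Compound 1 carries a limit and not a number: the limit of < 5 mg/kg in this assay, at which 1 of the 4 values shown sits. Isopropyl in place of trifluoromethyl therefore gives only a number no lower from compound 1 to compound 4 (the limit leaves the size open).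

Still open, as far as these compounds go, is how a longer chain such as butyl, or a tert-butyl or cyclopropyl group, would read at this place.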